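Ring-nitrogen substituent swap and tissue distribution

The compounds below may be only part of what the source reports. "The series", "measured", "known", "first", "only" and "open" are said of these compounds alone.

Three members of the series have been run in an in vivo ADME assay on the whole organism (strain Han Wistar) for pharmacokinetics, with Rattus norvegicus as the target; on this read-out higher numbers stand for wider distribution into tissues and lower numbers for narrower distribution. Compound 1 `CCCC[C@H](NC(=O)O[C@@H]1C(=O)N(C(=O)c2nnc(C(F)(F)F)s2)CC1(C)C)C(=O)C(=O)Nc1cc[nH]n1` gives 3.3 L/kg, compound 3 `CCCC[C@H](NC(=O)O[C@@H]1C(=O)N(C(=O)c2nc3ccccc3s2)CC1(C)C)C(=O)C(=O)Nc1cc[nH]n1` gives 2.2 L/kg, and compound 2 `CCCC[C@H](NC(=O)O[C@@H]1C(=O)N(S(=O)(=O)c2ccccc2)CC1(C)C)C(=O)C(=O)N[C@H](C)c1ccccc1` gives 2.1 L/kg. Compound 2 therefore holds the smallest of the three numbers, yet it lies within the scatter of both compound 3 and compound 1, so the three cannot be ranked.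

Compound 4 `CCCC[C@H](NC(=O)O[C@@H]1C(=O)N(C(=O)Nc2c(C)noc2C)CC1(C)C)C(=O)C(=O)N[C@H](C)c1ccccc1` differs from compound 2 in one place: (3,5-dimethyl-1,2-oxazol-4-yl)carbamoyl in place of phenylsulfonyl on an amide-type nitrogen in a ring. Among the compounds with values here, the only measured step at the same ring nitrogen is a 1.5-fold lower number from compound 1 to compound 3 (0.18 log units; within the scatter), a swap of one carbonyl-linked heteroaryl for another that left this assay unmoved. Within the data shown here, that step does not involve phenylsulfonyl or a carbamoyl group, so it bears on the present change only loosely, and no step touching either group is available.

Among the measured compounds shown here, with the one comparable step within the scatter, no shift beyond the scatter is expected for compound 4, and its value in this assay is estimated at 2.3 L/kg (range 1.1 L/kg to 4.8 L/kg). The expected step is a 1.1-fold higher number from compound 2 to compound 4 (0.04 log units; within the scatter), with wide uncertainty.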

Compound 4, volume of distribution at steady state: 1.4 L/kg
Beside the measured number, compound 4's estimate is 1.6-fold (0.22 log units) above it; the range from low to high includes it.
By their numbers in this assay, from the lowest: compounds 4, 2, 3 and 1 (each within the scatter of the next, the first and the last beyond it).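

In this assay, exchanging phenylsulfonyl for (3,5-dimethyl-1,2-oxazol-4-yl)carbamoyl on the amide-type nitrogen in a ring gives a 1.5-fold lower number from compound 2 to compound 4 (0.18 log units; within the scatter) and so does not register beyond the scatter. The earlier step at this nitrogen, a 1.5-fold lower number from compound 1 to compound 3 (0.18 log units; within the scatter), only swapped one carbonyl-linked heteroaryl for another, whereas this one replaces the sulfonyl link with a carbamoyl link and brings in a hydrogen-bond donor. Within the data shown here, both steps read at this position therefore stay within the scatter, including the one that changes the linking group.

Still open, from the compounds shown here alone, is whether a group carrying an amine or a carboxylic acid on this nitrogen, or a plain alkyl chain in place of the aromatic ring, would give a step beyond the scatter. Also open, going by these compounds, is whether the same exchange reads alike with the other amide end seen in compound 1 and compound 3. No measured evidence bears on the step.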